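This account rests on a few compounds, and the source may have more. Where it says the series, first, only, none or still open, it means among the compounds named here.

Measured compounds:
Compound 1 `O=C(O)c1cc(-c2cccc(COc3ccc4c(=O)n(C5CCC5)sc4c3)c2)ccc1Cl` gives 67%
Compound 2 `O=C1c2ccc(OCc3cccc(-c4ccc(C(F)(F)F)cc4F)c3)cc2CN1C1CCCC1` gives "not determined" (no result reported)

Within the data shown here, in an ADME assay on microsomes from liver (Rattus norvegicus) for metabolic stability, read by LC-MS, with a stated time of 1 h, at 37 degrees C, tested at 4 uM (a lower number here means that less of the compound is left, a higher number that more of the compound is left), compound 1 gives 67%, which is the only number in this set; compound 2 was run but returned no result, so nothing can be said of it beyond its structure. Compound 1 therefore stands alone, with no measured neighbour to set a scale for any change.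

Compound 3 `Cn1sc2cc(OCc3cccc(-c4ccc(Cl)c(C(=O)O)c4)c3)ccc2c1=O` differs from compound 1 in one place: methyl in place of cyclobutyl on an aromatic nitrogen. The step replaces the four-membered ring with a single carbon, leaving the rest of the shared core unchanged.

Among the measured compounds shown here, no step between two measured compounds exists here, so the size of this change in this assay can only be expected, not read off. A change of this kind, a smaller alkyl on the aromatic nitrogen, is expected to move the result only slightly, if at all, with a mild lean toward more compound remaining. The estimated step of a number 5 percentage points higher from compound 1 to compound 3 (within the scatter) is thus expected to be small, close to the scatter. Compound 3 is expected to give about 72%, with a range from 55% to 88%.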

Compound 3, percent of the compound remaining: 84%
The estimate for compound 3 lay 12 percentage points below the measured number; the measured number falls inside the stated range.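

In this assay, the aromatic nitrogen next to the ring sulfur now has its first measured step: methyl in place of cyclobutyl gives a number 17 percentage points higher from compound 1 to compound 3 (beyond the scatter), and the rest of the shared core stays the same. The step is modest but lies beyond the usual scatter, so this one position can alter how much of the compound remains in this assay, which a single value for compound 1 could not show. No measured evidence accounts for the step, so its cause remains unknown.

With only cyclobutyl and methyl measured at this position, the two results give a single comparison rather than a trend, and they do not show whether the result changes gradually or depends on the presence of a ring. Ethyl, isopropyl, cyclopropyl or a longer chain ending in a hydroxyl group on the same nitrogen would help separate these possibilities, while it also remains open whether the same change would give a similar step on a core carrying something other than the carboxylic acid.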